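Swapping Bromo for Trifluoromethyl on a Phenyl Ring

The compounds below may be only part of what the source reports. "The series", "measured", "known", "first", "only" and "open" are said of these compounds alone.

Three compounds have been measured in an ADME assay on L6 cells (Rattus norvegicus) for cytotoxicity, read by resazurin assay, with a stated time of 72 h; on this read-out higher numbers stand for weaker inhibition and lower numbers for stronger inhibition:
- Compound 1 `O=C1[C@H]2N=NN(Cc3nc(-c4ccccc4)no3)[C@H]2C(=O)N1c1ccccc1` gives 47.3 ug/mL.
- Compound 2 `O=C1[C@H]2N=NN(Cc3nc(-c4ccc(Br)cc4)no3)[C@H]2C(=O)N1c1ccccc1` gives 58.6 ug/mL.
- Compound 3 `O=C1[C@H]2N=NN(Cc3nc(-c4ccc(F)cc4)no3)[C@H]2C(=O)N1c1ccccc1` gives only a limit of the assay, > 100 ug/mL.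

Compound 2 holds the highest of the two plain numbers, with compound 1 nearest: a 1.2-fold higher number from compound 1 to compound 2 (0.09 log units; within the scatter). Compound 4 `O=C1[C@H]2N=NN(Cc3nc(-c4ccc(C(F)(F)F)cc4)no3)[C@H]2C(=O)N1c1ccccc1` differs from compound 2 at one place: trifluoromethyl in place of bromo on an aromatic carbon. Going by the values given here, earlier changes at this same aromatic carbon give the only guidance. Bromo in place of hydrogen gave a 1.2-fold higher number from compound 1 to compound 2 (0.09 log units; within the scatter); fluoro in place of hydrogen gave an at least 2.1-fold higher number from compound 1 to compound 3 (0.32 log units; beyond the scatter), ending at the limit of > 100 ug/mL in this assay, at which 1 of the 3 values shown sits; fluoro in place of bromo gave an at least 1.7-fold higher number from compound 2 to compound 3 (0.23 log units; that floor lies within the scatter). Among the compounds with values here, no trifluoromethyl step has been measured. A small step is therefore expected, a 1.0-fold higher number from compound 2 to compound 4 (0.01 log units; within the scatter), possibly reaching the limit again. Compound 4 is estimated at 60 ug/mL, with a range from 30 ug/mL to 100 ug/mL.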

Compound 4, half-maximal inhibitory concentration: 44.4 ug/mL
Compound 4: middle estimate off by 1.4-fold (0.13 log units), on the high side; measured number inside the range.
By their numbers in this assay, from the lowest: compounds 4, 1 and 2 (each within the scatter of the next). At a limit, above all of these: compound 3.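

In this assay, trifluoromethyl on this aromatic carbon gives a reading level with bromo (a 1.3-fold lower number from compound 2 to compound 4 (0.12 log units; within the scatter)) and with plain hydrogen (a 1.1-fold lower number from compound 1 to compound 4 (0.03 log units; within the scatter)). Among the four compounds, fluoro alone stands apart (an at least 2.2-fold lower number from compound 3 to compound 4 (0.35 log units; beyond the scatter)). For compound 3 the reading is a limit and not a number: the limit of > 100 ug/mL in this assay, at which 1 of the 4 values shown sits.

Still open, going by these compounds, is whether that separation belongs to fluoro alone or would be shared by other groups here. An amine, a carboxylic acid or a longer chain at this same aromatic carbon could fall with the other three compounds or apart from them.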